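Fluoro for 1H-1,2,3-triazol-4-yl: compound 3 to compound 4

A few compounds are considered here, and "the series" means these few. Any claim that something is new, unique, unknown or untested is made for them only; others in the source may bear on it.

In an ADME assay on microsomes from liver (Rattus norvegicus) for metabolic stability, read by LC-MS, using NADPH, with a stated time of 10 min, tested at 0.1 uM (on this read-out lower numbers stand for slow clearance and higher numbers for fast clearance), compound 1 `COc1ccc(F)cc1N1C(=O)CSC1c1cccc(C(=O)NCCCCc2ccccc2)c1` gives 2300 mL.min-1.g-1 and compound 2 `C#Cc1cc(C(=O)NCCCCc2ccccc2)cc(C2SCC(=O)N2c2ccccc2OC)c1` gives 2200 mL.min-1.g-1. Compound 3 `O=C(NCCCCc1ccccc1)c1cccc(C2SCC(=O)N2c2cccc(-c3c[nH]nn3)c2)c1`, at 742 mL.min-1.g-1, has the lowest of the three numbers, and it alone carries 1H-1,2,3-triazol-4-yl.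

The next change is fluoro in place of 1H-1,2,3-triazol-4-yl on an aromatic carbon, which leads to compound 4 `O=C(NCCCCc1ccccc1)c1cccc(C2SCC(=O)N2c2cccc(F)c2)c1`: fluoro in place of 1H-1,2,3-triazol-4-yl on an aromatic carbon, meta to a large group.

Within the data shown here, one measured step bears on this: a 3.1-fold lower number from compound 1 to compound 3 (0.49 log units; beyond the scatter). It is beyond the scatter and runs to a lower number as the group bearing 1H-1,2,3-triazol-4-yl enters. Among the measured compounds shown here, that step also changes other parts of the group, so it is only an imperfect guide, and no measured pair isolates the swap itself. Losing 1H-1,2,3-triazol-4-yl is expected to reverse most of that step. The expected step in this assay is a 2.6-fold higher number from compound 3 to compound 4 (0.41 log units; beyond the scatter), towards a higher number and beyond the scatter. For compound 4 the estimate is 1900 mL.min-1.g-1, with an expected range of 1000 mL.min-1.g-1 to 3500 mL.min-1.g-1.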

Compound 4, intrinsic clearance in microsomes: 3240 mL.min-1.g-1
Compound 4: the middle estimate sits 1.7-fold (0.23 log units) below what was measured, and the stated range covers the measured number.
By their numbers in this assay, from the lowest: compound 3; then compounds 2, 1 and 4 (each within the scatter of the next).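

The swap of fluoro for 1H-1,2,3-triazol-4-yl on an aromatic carbon, meta to a large group, isolates this position in this assay and gives a 4.4-fold higher number from compound 3 to compound 4 (0.64 log units; beyond the scatter). The step of hydrogen in place of methoxy, a 1.4-fold higher number from compound 1 to compound 4 (0.15 log units; within the scatter), lies within the scatter, so that change shows no readable effect on this read-out, and among the four compounds the low number stays with compound 3, the only one carrying 1H-1,2,3-triazol-4-yl. No supporting data explain the size of the swap.

Open, as far as these compounds go, is whether the lower number is particular to 1H-1,2,3-triazol-4-yl or would also appear with an amine, a carboxylic acid or a tetrazole on the same aromatic carbon. Also open, from the compounds shown here alone, is whether the step carries over to a compound with the ethynyl group of compound 2.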